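A Selenium-Bearing Group Added to Compound 2

The source may hold more compounds than are shown below. What is called first, only, known or untested is meant among the compounds shown, and "the series" means these compounds.

Among the compounds with values here, in a functional assay on LoVo cells (Homo sapiens) for inhibition, read by MTT assay, with a stated time of 48 h (on this read-out lower numbers stand for stronger inhibition and higher numbers for weaker inhibition), compound 2 `COc1ccc(N(C)c2nc(C)nc3ccccc23)cc1` gives 8 nM, the lower of the two numbers measured so far. Compound 1 `COc1ccc(N(C)c2nc(C)nc3ccccc23)cc1OCC[Se]C#N`, which carries a selenium-containing group on the same shared core, gives 19 nM in this assay.

The unmeasured compound 3 `COc1ccc(N(C)c2nc(C)nc3ccccc23)cc1C[Se]C#N` differs from compound 2 by one change: a group of 4 heavy atoms (2 carbon, 1 nitrogen, 1 selenium; no ring) in place of a hydrogen atom, on an aromatic carbon.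

Within the data shown here, only one measured step bears on this change. It replaces the selenium-containing group of compound 1 with a hydrogen atom, and the result is a 2.4-fold lower number from compound 1 to compound 2 (0.38 log units; beyond the scatter), a modest step beyond the scatter. Read in reverse, a 2.4-fold lower number from compound 1 to compound 2 (0.38 log units; beyond the scatter) suggests that adding the new group should bring a modest rise in the number. Among the measured compounds shown here, the entering group is not the same as the one in compound 1, however, and a single step cannot fix the size firmly, so the range is kept wide and reaches back to the value of compound 2.

The estimated change is a 2.4-fold higher number from compound 2 to compound 3 (0.38 log units; beyond the scatter). For compound 3, the expected value is 19 nM, with an estimated range of 7 nM to 55 nM.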

Compound 3, half-maximal inhibitory concentration: 277 nM
Beside the measured number, compound 3's estimate is 15-fold (1.16 log units) below it; measured number above the stated range.
By their numbers in this assay, from the lowest: compound 2; then compound 1; then compound 3.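

In this assay, within the data shown here, the selenium-bearing group of 4 heavy atoms on this aromatic carbon, ortho to a methoxy group, gives a 35-fold higher number from compound 2 to compound 3 (1.54 log units; beyond the scatter), a large step where the only earlier change at this place was modest. The two selenium-bearing groups therefore cannot be treated as equivalent at this position: exchanging the group of 6 heavy atoms for the group of 4 heavy atoms gives a 15-fold higher number from compound 1 to compound 3 (1.16 log units; beyond the scatter), so compound 1, with the larger group, stands closer to the unsubstituted compound 2 than compound 3 does. No measurement shown accounts for this difference between the two groups.

With only these two groups at this position, the compounds shown leave open whether the number changes steadily with the length of the chain that links the selenium to the ring, or whether compound 3 is a sharp exception to a tolerated series. They also leave open how a simple amine, a carboxylic acid or a longer chain ending in a nitrile would read at the same aromatic carbon, and whether a selenium-free chain of the same length would give a number like that of compound 3.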